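The compounds below may be only part of what the source reports. "The series", "measured", "known", "first", "only" and "open" are said of these compounds alone.

- Compound 1 `Cc1ccc(-c2cc(NC(=O)/C=C/c3ccc(Cl)cc3)n[nH]2)cc1`: 1490 nM
- Compound 2 `O=C(/C=C/c1ccc(Cl)cc1)Nc1cc(-c2ccc(Br)cc2)[nH]n1`: 1210 nM

Among the measured compounds shown here, only two compounds have numbers so far in a functional assay on A549 cells (Homo sapiens) for antiproliferative activity, read by MTT assay, with a stated time of 48 h; on this read-out higher numbers stand for weaker inhibition and lower numbers for stronger inhibition. For the measured compounds named here, the single measured step is a 1.2-fold lower number from compound 1 to compound 2 (0.09 log units; within the scatter), with bromo in place of methyl on an aromatic carbon. Compound 1, at 1490 nM, therefore cannot be ranked against compound 2, as the two numbers agree within the ordinary scatter of the measurement.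

The next compound, compound 3 `COc1ccc(/C=C/C(=O)Nc2cc(-c3ccc(C)cc3)[nH]n2)cc1`, keeps the methyl group of compound 1 and changes the other substituted phenyl group, from 4-chlorophenyl to 4-methoxyphenyl. It has methoxy in place of chloro on an aromatic carbon, para to a large group: methoxy in place of chloro on an aromatic carbon.

Going by the values given here, no measured step touches this position, so the data give no direct guide. The one indirect hint is that swapping a substituent elsewhere gave only a 1.2-fold lower number from compound 1 to compound 2 (0.09 log units; within the scatter). On that thin evidence, no step beyond the scatter is expected, and no direction can be favoured. The expected result is a 1.1-fold higher number from compound 1 to compound 3 (0.03 log units; within the scatter). For compound 3 the estimated value is 1600 nM, with an expected range from 600 nM to 4500 nM.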

Compound 3, half-maximal inhibitory concentration: 1190 nM
For compound 3 the middle estimate is 1.3-fold (0.13 log units) above the measured one, and the stated range covers the measured number.
By their numbers in this assay, from the lowest: compounds 3, 2 and 1 (each within the scatter of the next).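

Replacing the 4-chlorophenyl group with 4-methoxyphenyl in this assay gives a 1.3-fold lower number from compound 1 to compound 3 (0.10 log units; within the scatter). Among the compounds shown here, this is the first measured step at this position, and it shows that exchanging chloro for methoxy, which brings in a hydrogen-bond acceptor that chloro lacks, leaves the number inside the ordinary scatter, so the two groups cannot be told apart here. No separate measurement on these compounds helps to explain this result.

The compounds shown compare only chloro and methoxy at this position, so it remains open whether an amine, a carboxylic acid or a longer chain in that place would shift the number beyond the scatter. Also open, as far as these compounds go, is whether methoxy would read the same way with bromo rather than methyl on the other phenyl group, since a single step at each position cannot show how the two changes behave together.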